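Replacing a Pyrazole Side Group with Methoxyphenyl

The source may report more compounds than this note shows. Statements on the series, on what has been measured and on what is new or still open speak of the compounds shown alone.

Measured compounds:
compound 1, `Cc1cc(C)n(CCOC2CC(=O)Nc3c2c(C)nn3-c2ncnc3nc[nH]c23)n1`, 2000 nM
compound 2, `Cc1nn(-c2ncnc3nc[nH]c23)c2c1C(OCCn1nccc1C)CC(=O)N2`, 1620 nM

Both compounds share the same core and differ only in the side chain. In a functional assay on HEK293 cells for agonist activity at G-protein coupled receptor 39 (Homo sapiens), read by scintillation proximity assay and inositol phosphate accumulation, with a stated time of 75 min (on this read-out higher numbers stand for an effect only at larger amounts of compound and lower numbers for an effect already at smaller amounts), compound 1 gives 2000 nM, and compound 2 gives 1620 nM. For the measured compounds named here, the single measured step, a 1.2-fold lower number from compound 1 to compound 2 (0.09 log units; within the scatter), removes a methyl from an aromatic carbon. Compound 2 has the lower of the two numbers, but the gap to compound 1 lies within the scatter, so the two cannot be told apart.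

Compound 3, `COc1ccc(CCOC2CC(=O)Nc3c2c(C)nn3-c2ncnc3nc[nH]c23)cc1`, carries a different change: 4-methoxyphenyl in place of 5-methyl-1H-pyrazol-1-yl on a saturated chain carbon, two bonds along the chain from an oxygen on a saturated carbon. Going by the values given here, no measured step touches either the group that leaves or the group that enters; the only known step concerns a methyl elsewhere and was within the scatter. The direction of the new step is therefore open. Compound 3 is expected to give about 1600 nM, with a wide range from 300 nM to 8000 nM. This corresponds to an expected step of a 1.0-fold lower number from compound 2 to compound 3 (0.01 log units; within the scatter).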

Compound 3, half-maximal effective concentration: 70 nM
Compound 3: the middle estimate sits 23-fold (1.36 log units) above what was measured; the whole stated range lies above it.
By their numbers in this assay, from the lowest: compound 3; then compounds 2 and 1 (each within the scatter of the next).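

The group at the end of this chain clearly matters in this assay: changing the methyl on the pyrazole made no readable difference, yet 4-methoxyphenyl in place of 5-methyl-1H-pyrazol-1-yl gives a 23-fold lower number from compound 2 to compound 3 (1.36 log units; beyond the scatter) and so moves the number far more. The same kind of swap starting from 3,5-dimethyl-1H-pyrazol-1-yl gives a 29-fold lower number from compound 1 to compound 3 (1.46 log units; beyond the scatter) and shows that the drop holds for both pyrazoles shown. No measurement here explains why the number falls.

Compound 3 brings in a carbon-only ring and a methoxy group together, so the compounds shown cannot tell which of the two accounts for the drop. A plain phenyl group would help separate them, while a hydroxyl or an amine in place of the methoxy, or a longer chain, would test how far the change can be taken.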